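Amide nitrogen substituent and Toll-like receptor 2 agonism

The source may hold more compounds than are shown below. What is called first, only, known or untested is meant among the compounds shown, and "the series" means these compounds.

Among the compounds with values here, compound 2 `CCCCCCCCCCCC(=O)OC[C@H](CSC[C@@H](N)C(=O)NC(C)CCC(C)C)OC(=O)CCCCCCCCCCC` gives 190 nM in an assay on HEK293 cells for agonist activity at Toll-like receptor 2 (Homo sapiens) (a higher number here means that more compound is needed for the effect, a lower number that less compound is needed), the lowest of the two numbers so far; compound 1 `CCCCCCCCCCCC(=O)OC[C@H](CSC[C@@H](N)C(=O)NC(C)(C)CO)OC(=O)CCCCCCCCCCC` gives 15500 nM. Within the data shown here, the only measured step, an 82-fold lower number from compound 1 to compound 2 (1.91 log units; beyond the scatter), replaced a hydroxymethyl-bearing group by a plain branched alkyl. Compound 3 `CCCCCCCCCCCC(=O)OC[C@H](CSC[C@@H](N)C(=O)NCCCCCCCCCC(=O)O)OC(=O)CCCCCCCCCCC` moves the other way: 9-carboxynonyl in place of 1,4-dimethylpentyl on an amide-type nitrogen. Among the measured compounds shown here, no measured step covers this exact exchange, so the expectation is rough and rests on that single step pointing toward a higher number for a polar group on this nitrogen. The step in this assay is expected to be a 16-fold higher number from compound 2 to compound 3 (1.20 log units; beyond the scatter). Compound 3 is estimated at 3000 nM, with a range from 500 nM to 20000 nM.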

Compound 3, half-maximal effective concentration: 4400 nM
The estimate for compound 3 lay 1.5-fold (0.17 log units) below the measured number, and the stated range covers the measured number.
By their numbers in this assay, from the lowest: compound 2; then compound 3; then compound 1.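

On the amide-type nitrogen, 9-carboxynonyl in place of 1,4-dimethylpentyl gives, in this assay, a 23-fold higher number from compound 2 to compound 3 (1.36 log units; beyond the scatter). Against 1-(hydroxymethyl)-1-methylethyl, the same chain gives a 3.5-fold lower number from compound 1 to compound 3 (0.55 log units; beyond the scatter), so the two oxygen-bearing groups are separated and both stand above the plain 1,4-dimethylpentyl group, with no compound here going against that order. Nothing available explains this order.

Open, on these data alone, is whether the terminal carboxylic acid or the chain length sets the number of compound 3. A plain decyl chain, a methyl ester or a terminal amine would separate the two.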